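A few compounds are considered here, and "the series" means these few. Any claim that something is new, unique, unknown or untested is made for them only; others in the source may bear on it.

Compound 1 `C=C[C@@](C)(/C=C/c1ccc(O)c(C=O)c1)CCC=C(C)C` and compound 2 `C=C[C@@](C)(/C=C/c1ccc(O)c(/C=C/C(=O)OCc2ccccc2)c1)CCC=C(C)C` are the two members of this small series measured so far. For the measured compounds named here, in a functional assay on NALM-6 cells (Homo sapiens) for cytotoxicity, with a stated time of 72 h (on this read-out lower numbers stand for an effect already at smaller amounts and higher numbers for an effect only at larger amounts of compound), compound 1 gives 11200 nM, the only true number available. Compound 2 gives > 43400 nM, which is a limit of the assay and not a number. Its real position is therefore unknown, and the assay records no measurable value for it.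

The next compound, compound 3 `C=C[C@@](C)(/C=C/c1ccc(O)c(/C=C/C(N)=O)c1)CCC=C(C)C`, keeps the shared core and the double-bonded chain but changes the group at its end: amino in place of benzyloxy on a carbonyl carbon. In short, benzyloxycarbonyl gives way to carbamoyl.

Going by the values given here, no measured pair shows what this swap does, so any forecast is rough. A modest move toward lower numbers seems the more likely outcome, and the expected step is an at least 1.7-fold lower number from compound 2 to compound 3 (0.23 log units; that floor lies within the scatter). That expectation leans on compound 1, whose 11200 nM shows that a measurable effect is possible in this family. A result that again ends in a limit would be no surprise.

The estimated value for compound 3 is 25000 nM, with an expected range from 10000 nM to 60000 nM.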

Compound 3, half-maximal effective concentration: > 43400 nM
Compound 3 ended at the assay's limit; the forecaster's own chance of this, stated with the estimate: 40%; middle value at least 1.7-fold (0.23 log units) away from the limit.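

The step from compound 2 to compound 3 cannot be read, because both compounds end in a limit of the assay and not in a number: the limit of > 43400 nM in this assay, at which 2 of the 3 values shown sit.

Replacing benzyloxy with amino on a carbonyl carbon removes the aromatic ring and most of the group's heavy atoms, yet compound 3 in this assay still gives no measurable value, so the large benzyloxy group alone does not account for the limit seen with compound 2. The comparison with compound 1 is the readable one: 2-carbamoylethenyl in place of formyl on an aromatic carbon gives an at least 3.8-fold higher number from compound 1 to compound 3 (0.58 log units; beyond the scatter).

On these data alone, it remains open whether the double-bonded chain itself costs the effect or whether the groups at its end do, and how far compound 2 and compound 3 truly differ is unknown. A hydroxy group on the same carbonyl carbon, which would make a carboxylic acid, or a methylamino group there could help show whether any end group brings the value back into the measurable range.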